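The source may report more compounds than this note shows. Statements on the series, on what has been measured and on what is new or still open speak of the compounds shown alone.

Three analogues of the shared core have been measured in a functional assay on thoracic aorta (Rattus norvegicus) for inhibition; on this read-out lower numbers stand for an effect already at smaller amounts and higher numbers for an effect only at larger amounts of compound. Compound 1 `CC1(C)CC(NC(=S)Nc2cccc(C#N)c2)c2cc(NS(C)(=O)=O)ccc2O1` gives 9800 nM. Compound 2 `CC1(C)CC(NC(=S)Nc2ccc(Cl)cc2)c2cc(NS(C)(=O)=O)ccc2O1` gives 11600 nM. Compound 3 `CC1(C)CC(NC(=O)Nc2cccc(C#N)c2)c2cc(NS(C)(=O)=O)ccc2O1` gives 9300 nM, the lowest of the three numbers, though its gaps to compound 1 and to compound 2 are both within the scatter, so no order among the three can be read from them.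

Compound 4 `CC1(C)CC(NC(=O)Nc2cccc(Cl)c2)c2cc(NS(C)(=O)=O)ccc2O1` has not been measured in this assay. It differs from compound 3 by chloro in place of cyano on an aromatic carbon. Going by the values given here, the only measured step that bears on this exchange is a 1.2-fold higher number from compound 1 to compound 2 (0.07 log units; within the scatter), which replaces a 3-cyanophenyl by a 4-chlorophenyl on an amide-type nitrogen; that step stayed within the scatter. Among the compounds with values here, the comparison is imperfect, since it changes both the substituent and where it sits, and no measured pair exchanges cyano for chloro at the same place on the same core as compound 3. Within the data shown here, with that pair as the only guide, the step from compound 3 to compound 4 is expected to stay within the scatter in this assay, a 1.1-fold higher number from compound 3 to compound 4 (0.05 log units; within the scatter). Compound 4 is therefore estimated at 10500 nM, with a range from 5000 nM to 22000 nM.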

Compound 4, half-maximal effective concentration: 15200 nM
Compound 4: middle estimate off by 1.4-fold (0.16 log units), on the low side; the range from low to high includes it.
By their numbers in this assay, from the lowest: compounds 3, 1, 2 and 4 (each within the scatter of the next).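

Working notes on the 3-cyanophenyl to 3-chlorophenyl exchange: in this assay this exchange gives a 1.6-fold higher number from compound 3 to compound 4 (0.21 log units; within the scatter) and is the first step in the series that replaces cyano by chloro on the same aromatic carbon of the same core, so the group is changed without any change of place. The step stays within the scatter, so on this core the number does not depend measurably on the choice between these two groups, even though the nitrile brings a triple bond and a hydrogen-bond acceptor that chloro does not. With a 1.2-fold higher number from compound 1 to compound 2 (0.07 log units; within the scatter) also within the scatter, neither the step that changes group and place together nor the step that changes the group alone separates the compounds, and no line of measured evidence explains the result.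
Going by these compounds, it remains open whether an amine, a carboxylic acid or a longer chain such as an ethoxy group on this aromatic carbon would produce a step beyond the scatter. On these data alone, it also remains open whether the exchange of cyano for chloro gives a step of similar size on the core of compound 1, which carries a thiocarbonyl in place of the carbonyl.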